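The source may report more compounds than this note shows. Statements on the series, on what has been measured and on what is new or still open speak of the compounds shown alone.

Working notes on the series.

Of the compounds shown here, three of the shared core have been measured in a functional assay on MDA-MB-231 cells (Homo sapiens) for antiproliferative activity, read by MTT assay, with a stated time of 24 h; on this read-out lower numbers stand for stronger inhibition and higher numbers for weaker inhibition. Compound 1 `COc1ccc(-c2cc(/C=C/C(=O)c3cc(OC)c(OC)c(OC)c3)nc3cc(-c4ccccc4)nn23)cc1OC` gives 4700 nM in this assay, the lowest of the three numbers. Compound 2 `COc1ccc(-c2cc(/C=C/C(=O)c3ccc(OC)c(OC)c3)nc3cc(-c4ccccc4)nn23)cc1` gives 8700 nM in this assay, a number that lies within the scatter of compound 1. Compound 3 `COc1cc(-c2cc(/C=C/C(=O)c3ccc(C)c(C)c3)nc3cc(-c4ccccc4)nn23)cc(OC)c1OC` gives 13500 nM in this assay, which stands beyond the scatter above compound 1. No pair among these three differs in one place only, so no single step can be read from them directly; compound 2 and compound 3 each carry changes on both outer rings relative to compound 1.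

Compound 4 `COc1ccc(C(=O)/C=C/c2cc(-c3ccc(OC)c(OC)c3)n3nc(-c4ccccc4)cc3n2)cc1` has not yet been measured. It differs from compound 1 as follows: 4-methoxyphenyl in place of 3,4,5-trimethoxyphenyl on a carbonyl carbon

Compound 2 and compound 3, which carry fewer methoxy groups on the ring attached to the carbonyl carbon, give higher numbers than compound 1 in this assay. On that basis a modest rise is expected for compound 4 in this assay, with the step estimated at a 1.9-fold higher number from compound 1 to compound 4 (0.28 log units; within the scatter), near the edge of the scatter. The estimate for compound 4 in this assay is 9000 nM, with a range from 4000 nM to 25000 nM.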

Compound 4, half-maximal inhibitory concentration: 13900 nM
Beside the measured number, compound 4's estimate is 1.5-fold (0.19 log units) below it; the measured number falls inside the stated range.
By their numbers in this assay, from the lowest: compounds 1, 2, 3 and 4 (each within the scatter of the next, the first and the last beyond it).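

In this assay, among the compounds shown here, the change of 4-methoxyphenyl in place of 3,4,5-trimethoxyphenyl on a carbonyl carbon gives a 3.0-fold higher number from compound 1 to compound 4 (0.47 log units; beyond the scatter) and is the first step that can be read in one place. With the rest of compound 1 held fixed, the group on this carbonyl carbon alters the number by itself and beyond the scatter, which compound 2 and compound 3, each changed on both outer rings, could not show. No measurement at hand bears on why this step has its size.

Still open, going by these compounds, is whether the rise follows the count of methoxy groups on this ring or the loss of one particular methoxy group, and whether the step keeps its size when the other outer ring of compound 1 is different. Also open is how this position answers to substituents of another kind on the ring, such as a dimethylamino group, a carboxylic acid or a longer alkoxy chain, since the compounds shown offer no comparison for any of them.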